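Exchanging an Azido Arm for a Sulfonylamino Arm

The source may report more compounds than this note shows. Statements on the series, on what has been measured and on what is new or still open speak of the compounds shown alone.

Measured so far in an ADME assay on microsomes from liver (Homo sapiens) for metabolic stability, read by LC-MS, using NADPH, tested at 5 uM; a higher number here means that the compound lasts longer, a lower number that the compound disappears faster:
compound 1, `Cc1ccc(C)c(N2CCN(Cc3nnc(-c4cc(S(N)(=O)=O)c(SCc5ccccc5)cc4Cl)o3)CC2)c1`, gives 0.208 h
compound 2, `[N-]=[N+]=NCc1nnc(-c2cc(S(N)(=O)=O)c(SCc3ccccc3)cc2Cl)o1`, gives > 1 h

For compound 2 the value is a limit of this assay and not a number, so compound 2 stands only at the edge of what the measurement can report (the limit of > 1 h in this assay, at which 1 of the 2 values shown sits). Compound 1 sits well inside the range. Among the measured compounds shown here, no single-change pair links the two, so the account moves directly from compound 2 to the unmeasured compound 3, `NS(=O)(=O)c1cc(-c2nnc(CNS(=O)(=O)c3ccc(Cl)cc3)o2)c(Cl)cc1SCc1ccccc1`. The change is ((4-chlorophenyl)sulfonyl)amino in place of azido on a saturated chain carbon bound to an aromatic carbon. For the measured compounds named here, since nothing among the measured compounds mirrors this exchange, the step of an at least 1.4-fold lower number from compound 2 to compound 3 (0.15 log units; that floor lies within the scatter) is put forward as an expectation of a shortening in this assay that goes beyond the usual scatter, though with wide uncertainty. Compound 3 is therefore estimated at 0.7 h, within a range from 0.25 h to 2 h.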

Compound 3, half-life: 0.197 h
For compound 3 the middle estimate is 3.6-fold (0.55 log units) above the measured one; the whole stated range lies above it.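

In this assay, ((4-chlorophenyl)sulfonyl)amino in place of azido on a saturated chain carbon bound to an aromatic carbon gives an at least 5.0-fold lower number from compound 2 to compound 3 (0.70 log units; beyond the scatter). The earlier compounds shown here offered no single-change pair, so they could not show that the half-life responds to an exchange at this place at all. The size of the step is a floor and not an exact distance, since the value of compound 2 is a limit and not a number: the limit of > 1 h in this assay, at which 1 of the 3 values shown sits.

The compounds shown leave open which part of the entering arm goes with the shorter half-life, the sulfonylamino link or the 4-chlorophenyl ring. A phenylsulfonylamino arm without the chlorine, or a methylsulfonylamino arm at the same place, would begin to separate the two.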